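Cyclopropyl in Place of Propyl on the Amide Nitrogen

The source may report more compounds than this note shows. Statements on the series, on what has been measured and on what is new or still open speak of the compounds shown alone.

Measured in a functional assay on the whole organism with Rattus norvegicus as the target, at a dose of 20 mg/kg by the oral route; on this read-out higher numbers stand for more inhibition at the one dose given (going by the name of the read-out) and lower numbers for less inhibition:
compound 1, `CC(C)NC(=O)/C=C1\CCc2ccc(F)cc21`: 71%
compound 2, `O=C(/C=C1\CCc2ccc(F)cc21)N1CCC1`: 0%
compound 3, `CCCNC(=O)/C=C1\CCc2ccc(F)cc21`: 36%

Compound 3 stands second of these three in this assay, with compound 1 higher and compound 2 lower, both gaps beyond the scatter. Compound 4, `O=C(/C=C1\CCc2ccc(F)cc21)NC1CC1`, is not yet measured and differs from compound 3 in one place: cyclopropyl in place of propyl on an amide-type nitrogen. For the measured compounds named here, two measured steps touch the same amide-type nitrogen. The step of a number 35 percentage points lower from compound 1 to compound 3 (beyond the scatter) shows that trading isopropyl for propyl cost a large amount, and the step of a number 36 percentage points higher from compound 2 to compound 3 (beyond the scatter) shows that a propylamino group recovers much of what the azetidin-1-yl group lacks. Going by the values given here, no measured step involves cyclopropyl, so its effect can only be guessed from the fact that compound 1 and compound 3 both keep the amide hydrogen and sit well above compound 2. The change to compound 4 is expected to give a moderate rise, a number 14 percentage points higher from compound 3 to compound 4 (beyond the scatter), that may or may not clear the scatter. Compound 4 is therefore estimated at 50%, within 20% to 80%.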

Compound 4, a percentage reported as inhibition, in the whole organism at one dose (the size of the read-out at that dose, not a potency): 7%
Compound 4: middle estimate off by 43 percentage points, on the high side; measured number outside the range, below it.
By their numbers in this assay, from the lowest: compounds 2 and 4 (each within the scatter of the next); then compound 3; then compound 1.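

In this assay, closing the three carbons of propyl into a cyclopropyl ring on the amide-type nitrogen leaves the heavy-atom count unchanged yet gives a number 29 percentage points lower from compound 3 to compound 4 (beyond the scatter), so keeping the amide hydrogen does not by itself hold the effect at this position. The step to the branched chain's counterpart is larger still, a number 64 percentage points lower from compound 1 to compound 4 (beyond the scatter), whereas cyclopropylamino and azetidin-1-yl on the carbonyl carbon cannot be told apart, a number 7 percentage points higher from compound 2 to compound 4 (within the scatter). No evidence here bears on why the cyclopropyl ring fares so differently from the open chains.

Going by these compounds, whether this drop belongs to cyclopropyl alone or extends to larger rings on this nitrogen stays open, and a cyclobutyl or cyclopentyl group would address that. A tert-butyl group would show whether further branching goes beyond isopropyl, and all these readings rest on a single oral dose.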